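The source may report more compounds than this note shows. Statements on the series, on what has been measured and on what is new or still open speak of the compounds shown alone.

Compound 1, `COc1cc(-c2nn(-c3ccc(NC(=O)Nc4ccc(Cl)c(Cl)c4)cc3)cc2-c2ccncc2)ccc1Cl`, gives 2560 nM in a functional assay on M14 cells (Homo sapiens) for antiproliferative activity, read by sulforhodamine B assay, with a stated time of 48 h; a lower number here means a stronger inhibitor, a higher number a weaker inhibitor.
Compound 2, `COc1cc(-c2nn(-c3ccc(NC(=O)Nc4ccc(Cl)c(C(F)(F)F)c4)cc3)cc2-c2ccncc2)ccc1Cl`, gives 1740 nM in this assay.

Of the two numbers measured, the number for compound 2 is the lower one, its nearest neighbour being compound 1; the step of a 1.5-fold lower number from compound 1 to compound 2 (0.17 log units; within the scatter) lies within the scatter, so the two compounds cannot be set in order on this evidence. Compound 3, `O=C(Nc1ccc(-n2cc(-c3ccncc3)c(-c3ccc(Cl)c(O)c3)n2)cc1)Nc1ccc(Cl)c(C(F)(F)F)c1`, differs from compound 2 in one place: hydrogen in place of methyl on an oxygen on an aromatic ring. Among the compounds with values here, the only measured step, from compound 1 to compound 2, concerns a different position on the other end of the molecule and does not bear on a change at this oxygen, so no measured evidence speaks for a shift in either direction in this assay. Compound 3 is therefore expected to lie close to compound 2, with an estimated step of no change at the digits printed from compound 2 to compound 3 (within the scatter) that stays within the scatter, giving an estimate of 1740 nM with a range from 600 nM to 5000 nM.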

Compound 3, half-maximal inhibitory concentration: 1430 nM
Compound 3: the middle estimate sits 1.2-fold (0.09 log units) above what was measured, within the range that was stated.
By their numbers in this assay, from the lowest: compounds 3, 2 and 1 (each within the scatter of the next).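

In this assay the change from methoxy to hydroxy gives a 1.2-fold lower number from compound 2 to compound 3 (0.09 log units; within the scatter), so compound 2 and compound 3 cannot be set in order. Within the data shown here, the earlier step concerned the exchange of chloro for trifluoromethyl at another place, whereas this is the first reading at the oxygen on the aromatic ring; it shows that, with this compound pair, replacing methyl by hydrogen there gives a step that stays within the scatter. Nothing measured here offers an explanation for this result.

The compounds shown leave open whether a longer chain on this oxygen, such as ethyl or propyl, or an amine in place of the hydroxy group, would give a step beyond the scatter. They also leave open whether the same change would read alike with the chloro group of compound 1 in place of trifluoromethyl.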